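Methylsulfonyl on the Ring Nitrogen: What to Expect

The source may hold more compounds than are shown below. What is called first, only, known or untested is meant among the compounds shown, and "the series" means these compounds.

Compound 1 `COc1ccc(/C=C2\CCC=CC2=O)cc1OC` has no nitrogen in its non-aromatic ring. In a functional assay on MCF7 cells (Homo sapiens) for antiproliferative activity, read by sulforhodamine B assay, with a stated time of 72 h (a higher number here means a weaker inhibitor, a lower number a stronger inhibitor), compound 1 gives 5230 nM. Compound 2 `COc1cc(/C=C2\CN(C(=O)OCc3ccccc3)C=CC2=O)cc(OC)c1OC` carries a benzyloxycarbonyl group on the amine nitrogen in its ring. In this assay compound 2 reaches only the limit of the assay, > 25000 nM. Compound 3 `COc1cc(/C=C2\CNC=CC2=O)cc(OC)c1OC` bears hydrogen on that nitrogen. In this assay compound 3 likewise reaches only the limit, > 25000 nM, so no number is known for it. The step that the two limits leave unreadable from compound 2 to compound 3 therefore has no readable size. Compound 3 stands at the limit of > 25000 nM in this assay, at which 2 of the 3 values shown sit.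

Compound 4 `COc1cc(/C=C2\CN(S(C)(=O)=O)C=CC2=O)cc(OC)c1OC` differs from compound 3 in one place: methylsulfonyl in place of hydrogen on an amine nitrogen in a ring. Among the compounds with values here, the only measured step at this nitrogen, from a carbonyl-bearing group to hydrogen, is unreadable, so no measured step gives a size to expect. Within the data shown here, both a substituted and an unsubstituted nitrogen gave only limits, and compound 1, which lacks this nitrogen, is the single compound with a number. The step of a number no higher from compound 3 to compound 4 (the limit leaves the size open) is therefore expected to be none beyond the scatter, with the result most likely reported again only as a limit. Compound 4 is expected to give 25000 nM, within a range from 5000 nM to 100000 nM.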

Compound 4, half-maximal inhibitory concentration: 17600 nM
Compound 4: the middle estimate sits 1.4-fold (0.15 log units) above what was measured; the range from low to high includes it.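

Among the compounds shown with a nitrogen in this ring, compound 4 is the first to give a number rather than a limit in this assay, so a group on this nitrogen can bring the reading inside the range of the assay, although the benzyloxycarbonyl group of compound 2 does not. Set against the two limits, the result reads as an at least 1.4-fold lower number from compound 3 to compound 4 (0.15 log units; that floor lies within the scatter) and as an at least 1.4-fold lower number from compound 2 to compound 4 (0.15 log units; that floor lies within the scatter), and each of these sizes is only a floor, so the real step may be larger. Compound 2 and compound 3 both remain at the limit, which is why neither step has an upper size: the limit of > 25000 nM in this assay, at which 2 of the 4 values shown sit.

From the compounds shown here alone, the true values of compound 2 and compound 3 remain unknown, so the full size of both steps stays open, and the step between those two compounds cannot be read. Within the data shown here, also open is whether another group on this ring nitrogen, such as acetyl, methyl or the longer ethylsulfonyl, would give a number different from the one for compound 4, 17600 nM.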